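Cytotoxicity of hydrazone analogues: trading hydroxyls for a methoxy

The source may report more compounds than this note shows. Statements on the series, on what has been measured and on what is new or still open speak of the compounds shown alone.

Compound 1 `COc1ccccc1-c1nnc(-c2ccc(C(=O)N/N=C/c3ccccn3)cc2)o1`: 67000 nM
Compound 2 `COc1ccccc1-c1nnc(-c2ccc(C(=O)N/N=C/c3c(O)cc(O)cc3O)cc2)o1`: 12400 nM
Compound 3 `COc1ccccc1-c1nnc(-c2ccc(C(=O)N/N=C/c3ccc(O)c(O)c3)cc2)o1`: 100000 nM

Three measured compounds share a core and differ only in the aryl group on a carbon with a double bond to nitrogen. In an ADME assay on THP-1 cells (Homo sapiens) for cytotoxicity (a lower number here means a stronger inhibitor, a higher number a weaker inhibitor), compound 2 gives the lowest of the three numbers; its nearest neighbour is compound 1, a 5.4-fold lower number from compound 1 to compound 2 (0.73 log units; beyond the scatter), and the furthest is compound 3, an 8.1-fold higher number from compound 2 to compound 3 (0.91 log units; beyond the scatter). Compound 1 and compound 3 sit within the scatter of each other, a 1.5-fold higher number from compound 1 to compound 3 (0.17 log units; within the scatter).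

Compound 4 `COc1ccc(/C=N/NC(=O)c2ccc(-c3nnc(-c4ccccc4OC)o3)cc2)c(O)c1` is not yet measured. It differs from compound 2 in one place: 2-hydroxy-4-methoxyphenyl in place of 2,4,6-trihydroxyphenyl on a carbon with a double bond to nitrogen.

Among the measured compounds shown here, of the measured steps, the one from compound 2 to compound 3 bears most directly, since both remove hydroxyl groups from the ring and both of the remaining measured compounds lie well above compound 2. A modest rise is therefore expected in this assay, a 3.2-fold higher number from compound 2 to compound 4 (0.51 log units; beyond the scatter), though a methoxy is retained where compound 3 has only hydroxyls, so the step is expected to fall short of that to compound 3. Compound 4 is estimated at 40000 nM, within a range from 15000 nM to 100000 nM.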

Compound 4, half-maximal inhibitory concentration: 308000 nM
Compound 4: the middle estimate sits 7.7-fold (0.89 log units) below what was measured; the whole stated range lies below it.
By their numbers in this assay, from the lowest: compound 2; then compounds 1 and 3 (each within the scatter of the next); then compound 4.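

In this assay the aryl group on a carbon with a double bond to nitrogen proves more sensitive than the first three compounds suggested: 2-hydroxy-4-methoxyphenyl in place of 2,4,6-trihydroxyphenyl gives a 25-fold higher number from compound 2 to compound 4 (1.40 log units; beyond the scatter) and is the largest step yet seen at this position. Compound 4 also stands clear of the two compounds that lie within the scatter of each other, with a 3.1-fold higher number from compound 3 to compound 4 (0.49 log units; beyond the scatter) and a 4.6-fold higher number from compound 1 to compound 4 (0.66 log units; beyond the scatter) giving it the highest number of the four. Nothing available here accounts for the size of these steps.

Compound 4 differs from compound 2 both by carrying a methoxy and by having fewer hydroxyls, and the compounds shown do not separate these two changes. Also open, going by these compounds, is how this assay would read for an aryl group carrying an amine or a carboxylic acid.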